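Trading 1-benzofuran-5-yl for 1H-indazol-5-yl on a shared core

The source may hold more compounds than are shown below. What is called first, only, known or untested is meant among the compounds shown, and "the series" means these compounds.

Of the compounds shown here, three sharing one core have been measured in a functional assay on K562 cells (Homo sapiens) for inhibition, read by trypan blue exclusion, with a stated time of 72 h; a higher number here means a weaker inhibitor, a lower number a stronger inhibitor. Compound 1 `Cn1c(=O)c(S(=O)(=O)c2ccc(F)cc2F)cc2cnc(Nc3ccc4[nH]c(C(=O)O)cc4c3)nc21` gives 10000 nM, compound 2 `Cn1c(=O)c(S(=O)(=O)c2ccc(F)cc2F)cc2cnc(Nc3cccc4[nH]ccc34)nc21` gives 1500 nM, and compound 3 `Cn1c(=O)c(S(=O)(=O)c2ccc(F)cc2F)cc2cnc(Nc3ccc4occc4c3)nc21` gives 15000 nM. The last of these is the highest of the three numbers, yet the data show a 1.5-fold higher number from compound 1 to compound 3 (0.18 log units; within the scatter), a gap within the scatter. The clear separation lies elsewhere, with a 10-fold higher number from compound 2 to compound 3 (1.00 log units; beyond the scatter) and a 6.7-fold lower number from compound 1 to compound 2 (0.82 log units; beyond the scatter), both modest and beyond the scatter.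

Compound 4 `Cn1c(=O)c(S(=O)(=O)c2ccc(F)cc2F)cc2cnc(Nc3ccc4[nH]ncc4c3)nc21` departs from compound 3 by a single change: 1H-indazol-5-yl in place of 1-benzofuran-5-yl on a nitrogen on an aromatic ring. In words, this is 1H-indazol-5-yl in place of 1-benzofuran-5-yl on a nitrogen on an aromatic ring. Going by the values given here, no measured step makes this exact exchange, so the evidence is indirect. The step of a 10-fold higher number from compound 2 to compound 3 (1.00 log units; beyond the scatter) shows that the group on this nitrogen can matter, and it favours the 1H-indol-4-yl group of compound 2. Compound 1, with its 2-carboxy-1H-indol-5-yl group, goes against any simple rule, since a 1.5-fold higher number from compound 1 to compound 3 (0.18 log units; within the scatter) is no real change. A modest fall in the number is therefore expected, smaller than the largest step seen so far. The expected step is a 3.0-fold lower number from compound 3 to compound 4 (0.48 log units; beyond the scatter). For compound 4 the estimated value is 5000 nM, with an expected range from 1300 nM to 15000 nM.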

Compound 4, half-maximal inhibitory concentration: 50000 nM
Compound 4: the middle estimate sits 10-fold (1.00 log units) below what was measured; measured number above the stated range.
By their numbers in this assay, from the lowest: compound 2; then compounds 1 and 3 (each within the scatter of the next); then compound 4.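

In this assay, a 3.3-fold higher number from compound 3 to compound 4 (0.52 log units; beyond the scatter) shows that two groups on this nitrogen can be told apart even with the same count of heavy atoms, and that the hydrogen-bond donor entering with 1H-indazol-5-yl, absent from 1-benzofuran-5-yl, comes with no fall in the number. The earlier compounds had shown only compound 2 standing apart, whereas this position now gives a wider spread, with a 33-fold higher number from compound 2 to compound 4 (1.52 log units; beyond the scatter) as the largest step in the set and a 5.0-fold higher number from compound 1 to compound 4 (0.70 log units; beyond the scatter) separating two groups that both join the nitrogen as 5-yl groups. Nothing on hand accounts for these shifts.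

The compounds shown leave open whether the lower number of compound 2 goes with the 1H-indol-4-yl group as a whole or with its point of joining, a question that a plain 1H-indol-5-yl group or a 1H-indazol-4-yl group would address. Also open, going by these compounds, is how a methyl group on the ring nitrogen of 1H-indazol-5-yl, which would replace the hydrogen there, would read in this assay.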